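Aromatic nitrogen substituent and cell viability, compounds 1 to 3

The source may hold more compounds than are shown below. What is called first, only, known or untested is meant among the compounds shown, and "the series" means these compounds.

Measured so far:
compound 1 `O=C1COCCN1c1ccc(/N=C\c2c[nH]c3ccccc23)cc1` — 98.5%
compound 2 `O=C1COCCN1c1ccc(/N=C\c2cn(C(=O)c3ccc(Cl)cc3)c3ccccc23)cc1` — 90.1%

In an ADME assay on BV-2 cells (Mus musculus) for cytotoxicity, read by MTT assay, with a stated time of 48 h, tested at 10 uM (on this read-out lower numbers stand for a stronger effect and higher numbers for a weaker effect at the one concentration tested), compound 2 gives 90.1%, the lower of the two numbers recorded; its nearest neighbour is compound 1, and the two lie within the scatter of each other, so no order between them is claimed. Compound 3 `O=C1COCCN1c1ccc(/N=C\c2cn(Cc3ccc(F)cc3)c3ccccc23)cc1` is not yet measured. It differs from compound 2 in one place: 4-fluorobenzyl in place of (4-chlorophenyl)carbonyl on an aromatic nitrogen.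

Within the data shown here, the only step available is a number 8.4 percentage points lower from compound 1 to compound 2 (within the scatter), which swapped hydrogen on the same aromatic nitrogen for the (4-chlorophenyl)carbonyl group and stayed within the scatter. It bears on the new step only indirectly, since the group that now enters, 4-fluorobenzyl, has not been seen in this series. With both measured compounds close to one another in this assay, no step beyond the scatter is expected for compound 3, and the estimated change is a number 1.9 percentage points higher from compound 2 to compound 3 (within the scatter). Compound 3 is therefore estimated at 92%, with a range from 78% to 102%.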

Compound 3, a percentage reported as activity, at one concentration (the size of the read-out at that concentration, not a potency): 90%
For compound 3 the middle estimate is 2 percentage points above the measured one, and the stated range covers the measured number.
By their numbers in this assay, from the lowest: compounds 3, 2 and 1 (each within the scatter of the next).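

In this assay, a second large group on the aromatic nitrogen gives no step beyond the scatter: 4-fluorobenzyl in place of (4-chlorophenyl)carbonyl gives a number 0.1 percentage points lower from compound 2 to compound 3 (within the scatter). The comparison with hydrogen on the same nitrogen reads alike, with a number 8.5 percentage points lower from compound 1 to compound 3 (within the scatter), so a carbonyl in the group is not required for a number in this range, and the read-out does not separate hydrogen, (4-chlorophenyl)carbonyl and 4-fluorobenzyl at this position. No measurement at hand offers an explanation for this flat result.

From the compounds shown here alone, whether an aminoethyl chain or a carboxylic acid on this nitrogen would produce a step beyond the scatter remains open. Also open, going by these compounds, is what the fluorine and the chlorine each contribute, as the halogen and the carbonyl change together in the exchange between these two groups.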